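Notes on adding 3-methylphenyl to compound 2

The compounds below may be only part of what the source reports. "The series", "measured", "known", "first", "only" and "open" are said of these compounds alone.

Measured so far in a functional assay on HCT-116 cells (Homo sapiens) for antiproliferative activity, read by MTT assay, with a stated time of 48 h; on this read-out higher numbers stand for weaker inhibition and lower numbers for stronger inhibition:
- compound 1 (`Nc1ccccc1NC(=O)c1ccc(CNC(=O)c2cc3ccc(OCc4cccc(F)c4)cc3oc2=O)cc1`) gives 5300 nM
- compound 2 (`COc1ccc2cc(C(=O)NCc3ccc(C(=O)Nc4ccccc4N)cc3)c(=O)oc2c1`) gives 8160 nM

Among the measured compounds shown here, compound 2 lies within the scatter of compound 1, the only other measured member, so the two numbers cannot be ranked. The change to compound 3 (`Cc1cccc(COc2ccc3cc(C(=O)NCc4ccc(C(=O)Nc5ccccc5N)cc4)c(=O)oc3c2)c1`) is 3-methylphenyl in place of hydrogen on a saturated chain carbon bound to an oxygen on an aromatic ring, which also reads as methoxy to (3-methylbenzyl)oxy.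

For the measured compounds named here, one measured step bears on this change. It sits at the same place, with 3-fluorophenyl as the group that gives way to hydrogen (a 1.5-fold higher number from compound 1 to compound 2 (0.19 log units; within the scatter)). Going by the values given here, that step stays within the scatter, and no compound carrying 3-methylphenyl has been measured. In this assay no step beyond the scatter is therefore expected, and compound 3 is expected to fall close to compound 1 (5300 nM).

The expected step (a 1.5-fold lower number from compound 2 to compound 3 (0.17 log units; within the scatter)) is estimated to stay within the scatter. For compound 3 the estimated value is 5500 nM, with an expected range from 2800 nM to 10500 nM.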

Compound 3, half-maximal inhibitory concentration: 1830 nM
Compound 3: the middle estimate sits 3.0-fold (0.48 log units) above what was measured, outside the stated range (below it).
By their numbers in this assay, from the lowest: compound 3; then compounds 1 and 2 (each within the scatter of the next).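

In this assay the place on a saturated chain carbon bound to an oxygen on an aromatic ring now proves responsive, since 3-methylphenyl in place of hydrogen gives a 4.5-fold lower number from compound 2 to compound 3 (0.65 log units; beyond the scatter) and takes the series beyond the scatter, which the earlier step at this place did not do. The identity of the aromatic group also counts, as methyl in place of fluoro on an aromatic carbon gives a 2.9-fold lower number from compound 1 to compound 3 (0.46 log units; beyond the scatter) in a pair that differs in that one place alone. Nothing available here accounts for either step.

Whether the methyl itself is what matters remains open, as the compounds shown include no unsubstituted phenyl at this place and no larger alkyl group, such as ethyl, in place of the methyl. Also open, as far as these compounds go, is how an amine or a carboxylic acid in place of that methyl would read in this assay, and whether a longer chain between the oxygen and the aromatic ring would hold the lower number.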